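A few compounds are considered here, and "the series" means these few. Any claim that something is new, unique, unknown or untested is made for them only; others in the source may bear on it.

Compound 1 `N=C(N)c1cccc(CN2CC[C@H](NS(=O)(=O)c3ccc4cnccc4c3)C2=O)c1`: in an assay on isolated protein for binding affinity to serine protease 1 (Homo sapiens) (a lower number here means a stronger inhibitor, a higher number a weaker inhibitor), compound 1 gives > 2900 nM, which is a limit of the assay and not a number.
Compound 2 `N=C(N)c1cccc(CN2CC[C@H](NS(=O)(=O)c3ccc4ccnc(N)c4c3)C2=O)c1`: compound 2 gives > 2900 nM, again a limit.
Compound 3 `N=C(N)c1cccc(CN2CC[C@H](NS(=O)(=O)c3ccc4cccnc4c3)C2=O)c1`: compound 3 gives > 2900 nM, likewise a limit.

All three measured compounds sit at the limit of > 2900 nM in this assay, at which 3 of the 3 values shown sit, so none of them stands on a number. Compound 3 therefore stands at the limit, and the two further values shown are limits as well. Among the compounds with values here, the only step between measured compounds is a step that the two limits leave unreadable from compound 1 to compound 3, and it gives neither size nor direction. Compound 4 `N=C(N)c1cccc(CN2CC[C@H](NS(=O)(=O)c3ccc4ccc(Cl)nc4c3)C2=O)c1` differs from compound 3 by chloro in place of hydrogen on an aromatic carbon. Within the data shown here, no measured step bears on this change, as the one step available is unreadable. Nothing among the shown values speaks for a shift beyond the scatter, and nothing rules one out. Compound 4 is thus expected to stay near the limit, with the change from compound 3 to compound 4 estimated as a step that the limit leaves unreadable from compound 3 to compound 4. Compound 4 is estimated at 4000 nM, with a range from 1000 nM to 20000 nM.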

Compound 4, inhibition constant: > 2900 nM
Compound 4 ended at the assay's limit (the forecaster's own chance of this, stated with the estimate: 70%); the middle value lies beyond the limit too.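

Compound 3 and compound 4 both stand at a limit and not on a number, so no step between them can be read: the limit of > 2900 nM in this assay, at which 4 of the 4 values shown sit.

The compounds shown leave open whether chloro in place of hydrogen changes anything, and how strong any of the four compounds is in this assay.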